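Swapping cyclohexyl for benzyl on compound 3

The source may report more compounds than this note shows. Statements on the series, on what has been measured and on what is new or still open speak of the compounds shown alone.

Values so far in a physicochemical assay for solubility, read by nephelometry; on this read-out higher numbers stand for higher solubility and lower numbers for lower solubility:
- compound 1 `CN1CCN(c2cc(CN3C(=O)N(c4ccc(SC(F)(F)F)cc4)C(=O)C3(C)C)ccn2)CC1` gives 0.159 ug/mL
- compound 2 `CC1(C)C(=O)N(c2ccc(SC(F)(F)F)cc2)C(=O)N1Cc1ccnc(N2CCNCC2)c1` gives < 0.024 ug/mL (a limit, not a number)
- compound 3 `CC1(C)C(=O)N(c2ccc(SC(F)(F)F)cc2)C(=O)N1Cc1ccnc(NC2CCCCC2)c1` gives < 0.025 ug/mL (a limit, not a number)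

Compound 3 thus stands at a limit of the assay and has no measured number. Compound 4 `CC1(C)C(=O)N(c2ccc(SC(F)(F)F)cc2)C(=O)N1Cc1ccnc(NCc2ccccc2)c1` carries benzyl in place of cyclohexyl on a nitrogen on an aromatic ring. Two measured steps changed the group at this place. One was beyond the scatter (an at least 6.3-fold lower number from compound 1 to compound 3 (0.80 log units; beyond the scatter)), and the other cannot be read (a step that the two limits leave unreadable from compound 2 to compound 3). Neither exchanges cyclohexyl for benzyl. Since compound 3 gives < 0.025 ug/mL as its limit, no step beyond the scatter is expected in this assay and another limit is likely. The expected change is small (a step that the limit leaves unreadable from compound 3 to compound 4). Estimated for compound 4 is 0.02 ug/mL (range 0.008 ug/mL to 0.06 ug/mL).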

Compound 4, solubility: < 0.026 ug/mL
Compound 4 gave a limit, no number (the forecaster's own chance of this, stated with the estimate: 75%); the middle value lies beyond the limit too.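

Benzylamino in place of 4-methylpiperazin-1-yl gives an at least 6.1-fold lower number from compound 1 to compound 4 (0.78 log units; beyond the scatter) in this assay. An aromatic ring on this side chain therefore joins the saturated ring of compound 3 in falling short of a readable number, and among the compounds shown, only compound 1 gives one. The steps to compound 4 from compound 2 and from compound 3 cannot be read because both ends of each are limits: the limit of < 0.026 ug/mL in this assay, at which 1 of the 4 values shown sits.

Cyclohexylamino and benzylamino thus remain unranked. From the compounds shown here alone, whether morpholin-4-yl or dimethylamino on this aromatic carbon would give a readable number stays open.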